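Swapping Two Fluorines for Two Methyls on a Carboxylic Acid

The compounds below may be only part of what the source reports. "The series", "measured", "known", "first", "only" and "open" are said of these compounds alone.

Values from a functional assay on DU-145 cells (Homo sapiens) for cytotoxicity, read by trypan blue exclusion, with a stated time of 96 h (a lower number here means a stronger inhibitor, a higher number a weaker inhibitor), for three compounds

- compound 1 `COC(=O)C(F)(F)Nc1cc(CS(=O)(=O)/C=C/c2c(OC)cc(OC)cc2OC)ccc1OC` gives 250 nM
- compound 2 `COC(=O)C(Nc1cc(CS(=O)(=O)/C=C/c2c(OC)cc(OC)cc2OC)ccc1OC)c1ccccc1` gives 75 nM
- compound 3 `COc1cc(OC)c(/C=C/S(=O)(=O)Cc2ccc(OC)c(NC(F)(F)C(=O)O)c2)c(OC)c1` gives 150 nM

Compound 3 is second highest of the three numbers, but it cannot be separated from either of the others: a 1.7-fold lower number from compound 1 to compound 3 (0.22 log units; within the scatter) and a 2.0-fold higher number from compound 2 to compound 3 (0.30 log units; within the scatter) both stay within the scatter.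

The next compound, compound 4 `COc1cc(OC)c(/C=C/S(=O)(=O)Cc2ccc(OC)c(NC(C)(C)C(=O)O)c2)c(OC)c1`, carries 1-carboxy-1-methylethyl in place of carboxy(difluoro)methyl on a nitrogen on an aromatic ring. For the measured compounds named here, no measured pair makes this exact swap, so the evidence is indirect. The largest measured change at that nitrogen, a 3.3-fold lower number from compound 1 to compound 2 (0.52 log units; beyond the scatter), is modest, and it also removes the fluorines. That suggests a slight lean toward a lower number, though no shift beyond the scatter is expected. The estimated step is a 1.5-fold lower number from compound 3 to compound 4 (0.18 log units; within the scatter) and remains tentative. For compound 4 the expected value is 100 nM, with an estimated range from 35 nM to 300 nM as its likely span.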

Compound 4, half-maximal inhibitory concentration: 150 nM
For compound 4 the middle estimate is 1.5-fold (0.18 log units) below the measured one; the measured number falls inside the stated range.
By their numbers in this assay, from the lowest: compounds 2, 3, 4 and 1 (each within the scatter of the next, the first and the last beyond it).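

In this assay, for the compounds shown here, putting 1-carboxy-1-methylethyl in place of carboxy(difluoro)methyl on the nitrogen gives no change at the digits printed from compound 3 to compound 4 (within the scatter), the first direct reading of this swap, and it shows that the fluorines and the methyl groups cannot be told apart on the free acid. The two esters also stay close to the new compound, with a 2.0-fold higher number from compound 2 to compound 4 (0.30 log units; within the scatter) and a 1.7-fold lower number from compound 1 to compound 4 (0.22 log units; within the scatter), so its side chain cannot be separated from any of the others at this nitrogen. No measurement here bears on why these groups read so alike.

Still open, from the compounds shown here alone, is whether a simple amide or an amine on the same nitrogen would move the number beyond the scatter. A longer chain ending in the carboxylic acid, or the methyl ester of 1-carboxy-1-methylethyl, is equally untested among the compounds shown.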